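Adding a second acetoxy group to a weak plasma inhibitor

The source may hold more compounds than are shown below. What is called first, only, known or untested is meant among the compounds shown, and "the series" means these compounds.

Measured so far:
compound 1, `CC(=O)Oc1ccc(/C=C/C(=O)Nc2nccs2)cc1`, with 58100 nM
compound 2, `COc1cc(/C=C/C(=O)Nc2nccs2)cc(OC)c1OC`, with 18100 nM

Both compounds were tested in a functional assay on a cell-free system (plasma, Homo sapiens) for inhibition; a lower number here means a stronger inhibitor, a higher number a weaker inhibitor. Compound 1 gives 58100 nM, the highest of the two numbers, so it is the weaker inhibitor of the pair. Its nearest neighbour, compound 2, gives 18100 nM, a gap that lies beyond the usual scatter. Within the data shown here, the two compounds share a core but differ in several places at once, so no single step between them can be isolated; their two values alone show that compound 2 is the stronger inhibitor.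

The next compound, compound 3, `CC(=O)Oc1ccc(/C=C/C(=O)Nc2nccs2)cc1OC(C)=O`, is not yet measured. It differs from compound 1 in exactly one place: acetoxy in place of hydrogen on an aromatic carbon. Among the measured compounds shown here, with only two measured points, and none of them forming a one-step pair, there is no direct precedent for this change. The expectation is a small step, if any, toward a stronger inhibitor, likely within or only slightly beyond the scatter: a 1.5-fold lower number from compound 1 to compound 3 (0.16 log units; within the scatter). Compound 3 is therefore estimated at 40000 nM, with a plausible range from 12000 nM to 130000 nM.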

Compound 3, half-maximal inhibitory concentration: 75600 nM
Compound 3: the middle estimate sits 1.9-fold (0.28 log units) below what was measured; measured number inside the range.
By their numbers in this assay, from the lowest: compound 2; then compounds 1 and 3 (each within the scatter of the next).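

In this assay, putting acetoxy in place of hydrogen on an aromatic carbon, ortho to an acetoxy group, gives a 1.3-fold higher number from compound 1 to compound 3 (0.11 log units; within the scatter) and is the only one-place comparison among the compounds shown. Compound 1 at 58100 nM and compound 3 at 75600 nM therefore cannot be told apart, so on this core and at this position, the entering group with its 4 heavy atoms makes no measurable difference to inhibition. No supporting measurement is available to explain this result.

A hydroxy group, an amine or a carboxylic acid on the same aromatic carbon could give a different result, and one pair cannot show whether other groups at this position would also leave the number within the scatter. From the compounds shown here alone, compound 2, at 18100 nM, differs from compound 1 in several places, so its value does not show which of its changes matters, and the role of this position in a compound carrying methoxy groups remains open.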